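Dimethylamino for Chloro on the Pendant Phenyl

The source may report more compounds than this note shows. Statements on the series, on what has been measured and on what is new or still open speak of the compounds shown alone.

Among the compounds with values here, compound 2 `O=C1N=C(N2N=C(c3ccccc3)CC2c2ccc(Cl)cc2)S/C1=C1/C(=O)Nc2ccccc21` gives 850 nM in a functional assay on cells (Cancer cell lines, Homo sapiens) for cytotoxicity, read by sulforhodamine B assay, with a stated time of 48 h (on this read-out lower numbers stand for stronger inhibition of growth and higher numbers for weaker inhibition of growth), the lower of the two numbers so far, while compound 1 `O=C1N=C(N2N=C(c3ccccc3)CC2c2ccccc2O)S/C1=C1/C(=O)Nc2ccccc21` gives 4350 nM. Compound 3 `CN(C)c1ccc(C2CC(c3ccccc3)=NN2C2=NC(=O)/C(=C3\C(=O)Nc4ccccc43)S2)cc1` carries dimethylamino in place of chloro on an aromatic carbon. Within the data shown here, the only measured step at this ring, a 5.1-fold lower number from compound 1 to compound 2 (0.71 log units; beyond the scatter), shows that the group there can shift the number beyond the scatter, but nothing shows what a dimethylamino group does in this place. A shift of similar size in either direction is possible. Compound 3 is therefore expected near 1200 nM, within 400 nM to 4000 nM. This estimate amounts to a 1.4-fold higher number from compound 2 to compound 3 (0.15 log units; within the scatter).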

Compound 3, concentration for total growth inhibition: 34000 nM
The estimate for compound 3 lay 28-fold (1.45 log units) below the measured number; measured number outside the range, above it.
By their numbers in this assay, from the lowest: compound 2; then compound 1; then compound 3.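

In this assay the change from chloro to dimethylamino gives a 40-fold higher number from compound 2 to compound 3 (1.60 log units; beyond the scatter), a larger step than any seen earlier at this ring, so a single group on the pendant phenyl can move the number much further than compound 1 and compound 2 showed. Compound 3 also stands above the 2-hydroxyphenyl compound, with a 7.8-fold higher number from compound 1 to compound 3 (0.89 log units; beyond the scatter), which makes it the weakest of the three. Nothing available accounts for this shift. As far as these compounds go, whether a primary amine, a methoxy group or a carboxylic acid in the same place would fall nearer compound 2 or compound 3 remains open.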